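Swapping a Formyl for a Hydroxypyrrolidinylmethyl Arm

The source may hold more compounds than are shown below. What is called first, only, known or untested is meant among the compounds shown, and "the series" means these compounds.

Among the measured compounds shown here, compound 2 `COc1ccc(/C=C\c2cc(OC)c(OC)c(OC)c2)cc1OCc1ccc(C=O)cc1` is the one member of this small set with an actual number: in a functional assay on B16-F10 cells (Mus musculus) for antiproliferative activity, read by CCK-8 assay, with a stated time of 48 h (on this read-out lower numbers stand for stronger inhibition and higher numbers for weaker inhibition), compound 2 gives 4200 nM. Compound 1 `COc1ccc(/C=C\c2cc(OC)c(OC)c(OC)c2)cc1OCc1ccc(CNC(C)(C)C(=O)O)cc1` reaches only a limit of the assay, giving > 10000 nM in this assay. Compound 3 `COc1ccc(/C=C\c2cc(OC)c(OC)c(OC)c2)cc1OCc1ccc(CN[C@H](C(=O)O)[C@H](C)O)cc1` likewise sits at a limit, with > 10000 nM in this assay. The new compound 4 `COc1ccc(/C=C\c2cc(OC)c(OC)c(OC)c2)cc1OCc1ccc(CN2CC[C@@H](O)C2)cc1` alters the same spot on the shared core: (3-hydroxypyrrolidin-1-yl)methyl in place of formyl on an aromatic carbon. For the measured compounds named here, two measured steps touch this position. The swap an at least 2.3-fold lower number from compound 1 to compound 2 (0.37 log units; beyond the scatter) and the reverse swap an at least 2.3-fold higher number from compound 2 to compound 3 (0.37 log units; beyond the scatter) show that exchanging the formyl for a substituted aminomethyl group has twice pushed the value to the limit of > 10000 nM in this assay, at which 2 of the 3 values shown sit. Compound 4 also carries a substituted aminomethyl group, though its amine substituent differs from the 1-carboxy-1-methylethyl of compound 1 and the 1-carboxy-2-hydroxypropyl of compound 3. Compound 4 is therefore expected to land at a higher number, a 1.9-fold higher number from compound 2 to compound 4 (0.28 log units; within the scatter). Compound 4 is estimated at 8000 nM, within 2500 nM to 30000 nM.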

Compound 4, half-maximal inhibitory concentration: > 10000 nM
Compound 4 was reported as a limit; the forecaster's own chance of this, stated with the estimate: 40%; at least 1.2-fold (0.09 log units) between middle value and limit.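

Replacing the formyl with the (3-hydroxypyrrolidin-1-yl)methyl group gives an at least 2.3-fold higher number from compound 2 to compound 4 (0.37 log units; beyond the scatter) in this assay, and this arm has a five-membered non-aromatic ring and no carboxy group, unlike the amine arms of compound 1 and compound 3, so among these compounds the loss at this position does not require a carboxy group. Compound 4 therefore reaches a value that is a limit and not a number, as the two carboxy compounds did: the limit of > 10000 nM in this assay, at which 3 of the 4 values shown sit. The steps from compound 1 and from compound 3 to compound 4 join two limits and cannot be read, so these three compounds cannot be ranked.

As far as these compounds go, whether a smaller group, such as an unsubstituted aminomethyl or a hydroxymethyl, would keep the activity of compound 2 stays open. So does whether any replacement, such as a nitrile, could improve on the formyl.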